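The compounds below may be only part of what the source reports. "The series", "measured", "known", "first", "only" and "open" are said of these compounds alone.

In an ADME assay on Vero cells (Chlorocebus sabaeus) for cytotoxicity, read by MTT assay, with a stated time of 72 h (a higher number here means that more compound is tolerated, a lower number that less compound is tolerated), compound 1, whose structure is `O=C(COc1ccccc1C(=O)/C=C/c1ccc(Cl)cc1)NCCNc1ccnc2cc(Cl)ccc12`, gives 4980 nM. Two other compounds share its core and have also been measured. Compound 2, with the structure `O=C(/C=C/c1ccco1)NCCNc1ccnc2cc(Cl)ccc12`, gives 629000 nM, and compound 3, with the structure `COc1ccc(/C=C/C(=O)NCCNc2ccnc3cc(Cl)ccc23)cc1OC`, gives 5600 nM. Among these three numbers compound 1 has the lowest, so it is the one of which the cells tolerate the least. Its gap to compound 3 is within the scatter, so the two cannot be told apart on these data. Its gap to compound 2 lies well beyond the scatter: compound 2 is tolerated at a far higher concentration than compound 1.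

Compound 4, with the structure `COc1cc(/C=C/C(=O)c2ccccc2OCC(=O)NCCNc2ccnc3cc(Cl)ccc23)cc(OC)c1OC`, has not yet been measured in this assay. It differs from compound 1 in one place: 3,4,5-trimethoxyphenyl in place of 4-chlorophenyl on a double-bonded chain carbon bound to a double-bonded chain carbon. For the measured compounds named here, no pair of measured compounds shows this change on its own, so no step can be read off directly. Compound 3 carries two methoxy groups on a ring of this kind and is tolerated no differently from compound 1, so the step from compound 1 to compound 4 is expected to be small, a 1.4-fold higher number from compound 1 to compound 4 (0.15 log units; within the scatter), and likely not beyond the scatter. Compound 4 is therefore estimated at 7000 nM, with a range from 2500 nM to 20000 nM.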

Compound 4, half-maximal cytotoxic concentration: 3920 nM
The estimate for compound 4 lay 1.8-fold (0.25 log units) above the measured number; the range from low to high includes it.
By their numbers in this assay, from the lowest: compounds 4, 1 and 3 (each within the scatter of the next); then compound 2.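

Measured in this assay, putting 3,4,5-trimethoxyphenyl in place of 4-chlorophenyl gives a 1.3-fold lower number from compound 1 to compound 4 (0.10 log units; within the scatter) and this step lies within the usual scatter, so the cells cannot be said to tolerate the two compounds differently. For the compounds shown here, this is the first direct reading at this position, on a double-bonded chain carbon bound to a double-bonded chain carbon, and it shows that the group can go from 7 heavy atoms to 12 heavy atoms, and from 0 hydrogen-bond acceptors to 3 hydrogen-bond acceptors, with no difference that these data can resolve. No measurement shown here accounts for this result, so the reason remains unknown.

This single swap between two substituted rings sets no rule for the position, and the compounds shown do not tell whether an unsubstituted phenyl ring would fall in the same range. Nor do they show whether a group of a different kind at this place, such as an amine or a carboxylic acid, would keep the number in this range or move it beyond the scatter.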